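This account rests on a few compounds, and the source may have more. Where it says the series, first, only, none or still open, it means among the compounds named here.

In a functional assay on SW-620 cells (Homo sapiens) for cytotoxicity, read by MTT assay, with a stated time of 72 h (a lower number here means a stronger inhibitor, a higher number a weaker inhibitor), compound 1 `COc1cccc(/C=C2\CCC/C(=C\c3ccccc3Cl)C2=O)c1OC` gives 10300 nM, compound 2 `COc1cccc(/C=C2\CCC/C(=C\c3cccc(Cl)c3)C2=O)c1OC` gives 9100 nM and compound 3 `COc1cccc(/C=C2\CCC/C(=C\c3cccc(Br)c3)C2=O)c1OC` gives 8800 nM. Compound 3 therefore stands within the scatter of both other compounds. Compound 4 `COc1cccc(/C=C2\CCC/C(=C\c3ccc(Br)cc3)C2=O)c1OC` has 4-bromophenyl in place of 3-bromophenyl on a double-bonded chain carbon bound to a double-bonded ring carbon. Going by the values given here, three measured steps bear on this change: a 1.1-fold lower number from compound 1 to compound 2 (0.05 log units; within the scatter), a 1.2-fold lower number from compound 1 to compound 3 (0.07 log units; within the scatter) and a 1.0-fold lower number from compound 2 to compound 3 (0.01 log units; within the scatter). All three lie within the scatter, although none tests a 4-bromophenyl group directly. No change beyond the scatter is therefore expected, and the expected step is a 1.0-fold lower number from compound 3 to compound 4 (0.02 log units; within the scatter). For compound 4 the estimated value is 8500 nM, with an expected range of 4500 nM to 16000 nM.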

Compound 4, half-maximal inhibitory concentration: 11100 nM
Estimate against measurement, compound 4: 1.3-fold (0.12 log units) below; measured number inside the range.
By their numbers in this assay, from the lowest: compounds 3, 2, 1 and 4 (each within the scatter of the next).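

With 4-bromophenyl in place of 3-bromophenyl, a 1.3-fold higher number from compound 3 to compound 4 (0.10 log units; within the scatter) in this assay, so this change on the double-bonded chain carbon leaves the number within the scatter. The comparisons with the chlorophenyl compounds agree, with a 1.2-fold higher number from compound 2 to compound 4 (0.09 log units; within the scatter) and a 1.1-fold higher number from compound 1 to compound 4 (0.03 log units; within the scatter), so all four halogenated phenyl groups at this place read alike. Nothing available explains this result. The compounds shown leave open whether an amine or a carboxylic acid on this phenyl ring would shift the number beyond the scatter. They also leave open what a longer chain at this place would do.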